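The source may hold more compounds than are shown below. What is called first, only, known or untested is meant among the compounds shown, and "the series" means these compounds.

In a functional assay (trachea) with Cavia porcellus as the target (a lower number here means a stronger inhibitor, a higher number a weaker inhibitor), compound 1 (`C=CCn1nc(-c2cccnc2)c2ccccc2c1=O`) gives 2140 nM and compound 2 (`O=c1c2ccccc2c(-c2cccnc2)nn1Cc1cccc(Cl)c1`) gives 4170 nM. The step of a 1.9-fold higher number from compound 1 to compound 2 (0.29 log units; within the scatter) lies within the scatter. Compound 3 (`O=c1c2ccccc2c(-c2cccnc2)nn1CCSc1nccs1`) gives 10500 nM, the highest number of the three. Compound 4 (`O=C(O)CCCn1nc(-c2cccnc2)c2ccccc2c1=O`) differs from compound 3 as follows: carboxymethyl in place of (1,3-thiazol-2-yl)sulfanyl on a saturated chain carbon, two bonds along the chain from an aromatic nitrogen. The steps bearing on this change are a 4.9-fold higher number from compound 1 to compound 3 (0.69 log units; beyond the scatter) and a 2.5-fold higher number from compound 2 to compound 3 (0.40 log units; beyond the scatter), both modest, and neither involves a 3-carboxypropyl chain. As far as these compounds go, no step beyond the scatter is therefore expected in this assay, and the direction remains open. For compound 4, the estimated value is 8000 nM, with an expected range of 2500 nM to 30000 nM. The expected step is a 1.3-fold lower number from compound 3 to compound 4 (0.12 log units; within the scatter).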

Compound 4, half-maximal inhibitory concentration: > 100000 nM
Compound 4 ended at the assay's limit; the forecaster's own chance of this, stated with the estimate: 15%; middle value at least 12-fold (1.09 log units) away from the limit.
By their numbers in this assay, from the lowest: compounds 1 and 2 (each within the scatter of the next); then compound 3. At a limit, above all of these: compound 4.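

Compound 4 stands at a limit in this assay: the limit of > 100000 nM in this assay, at which 1 of the 4 values shown sits.

Vinyl, 3-chlorophenyl and the 2-((1,3-thiazol-2-yl)sulfanyl)ethyl chain had shown only small or modest steps at this position, whereas the 3-carboxypropyl chain gives an at least 9.5-fold higher number from compound 3 to compound 4 (0.97 log units; beyond the scatter), an at least 23-fold higher number from compound 2 to compound 4 (1.37 log units; beyond the scatter) and an at least 46-fold higher number from compound 1 to compound 4 (1.66 log units; beyond the scatter). The position therefore does not accept every chain equally in this assay.

As far as these compounds go, how far compound 4 lies past the limit remains open. Also open, from the compounds shown here alone, is whether the carboxylic acid itself or the chain carrying it sets this result, which an ethyl ester or primary amide on the same chain would address.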